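This account rests on a few compounds, and the source may have more. Where it says the series, first, only, none or still open, it means among the compounds named here.

Working notes on the series.

Compound 1 `NC1CCC(Nc2nc(NCc3ccc(-c4ccsc4)cc3)c3ncn(C4CCCC4)c3n2)CC1` is the reference; in a functional assay on HeLa cells (Homo sapiens) for inhibition, with a stated time of 72 h (on this read-out higher numbers stand for weaker inhibition and lower numbers for stronger inhibition), compound 1 gives 220 nM. Compound 2 `NC1CCC(Nc2nc(NCc3ccc(-c4ccsc4)nc3)c3ncn(C4CCCC4)c3n2)CC1` differs from compound 1 in its core, the change being (6-(thiophen-3-yl)pyridin-3-yl in place of 4-(thiophen-3-yl)phenyl on a saturated chain carbon bound to a nitrogen on an aromatic ring); in this assay compound 2 gives 75 nM, the step being a 2.9-fold lower number from compound 1 to compound 2 (0.47 log units; beyond the scatter). Compound 3 `NC1CCC(Nc2nc(NCc3ccc(-c4ccccc4O)cc3)c3ncn(C4CCCC4)c3n2)CC1` carries the change 2-hydroxyphenyl in place of thiophen-3-yl on an aromatic carbon relative to compound 1; in this assay compound 3 gives 4180 nM, a step of a 19-fold higher number from compound 1 to compound 3 (1.28 log units; beyond the scatter). Compound 2 stands lowest of the three measured numbers, with both steps to the others beyond the scatter.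

Compound 4 `NC1CCC(Nc2nc(NCc3ccc(-c4ccccc4O)nc3)c3ncn(C4CCCC4)c3n2)CC1` is not yet measured. It differs from compound 2 by 2-hydroxyphenyl in place of thiophen-3-yl on an aromatic carbon, the same kind of change as that from compound 1 to compound 3, but around the place the rings differ: on the core of compound 2 the place is on a six-membered aromatic ring with 1 nitrogen, next to the ring nitrogen, whereas on compound 1 it is on a six-membered aromatic ring of carbon only. The expectation for compound 4 is a step of a 19-fold higher number from compound 2 to compound 4 (1.27 log units; beyond the scatter) in this assay, resting on the step of a 19-fold higher number from compound 1 to compound 3 (1.28 log units; beyond the scatter) seen once, and estimated at 1400 nM for compound 4, with a range of 450 nM to 4500 nM.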

Compound 4, half-maximal inhibitory concentration: 16 nM
Compound 4: the middle estimate sits 88-fold (1.94 log units) above what was measured, and the stated range ends above it.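

In this assay the change does not carry from one core to the other: on the core of compound 2 the step is a 4.7-fold lower number from compound 2 to compound 4 (0.67 log units; beyond the scatter), which runs opposite in direction to the step on the core of compound 1, so the earlier step cannot be transferred between these cores: the same change on two cores in this assay, a 19-fold higher number (1.28 log units; beyond the scatter) from compound 1 to compound 3 and a 4.7-fold lower number (0.67 log units; beyond the scatter) from compound 2 to compound 4, 89-fold (1.95 log units) apart, beyond the scatter of two such steps. The two cores differ by the ring nitrogen, so the reversal goes with that one difference in this pair of steps. It does not show why the direction reverses, and a single step on each core gives no rule for other groups at this place or for other changes on these cores.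

On these data alone, it remains open whether the reversal belongs to the hydroxy group of 2-hydroxyphenyl or to the six-membered ring that carries it, which plain phenyl on both cores would help separate. As far as these compounds go, it is also open whether an amine or a carboxylic acid on that phenyl ring would show the same dependence on the core.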